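Swapping a lactam for a methylsulfonyl on a brominated catechol

The compounds below may be only part of what the source reports. "The series", "measured", "known", "first", "only" and "open" are said of these compounds alone.

Measured compounds:
Compound 1 `O=C1CCCN1Cc1c(Br)c(O)c(O)c(Br)c1Br`: 18500 nM
Compound 2 `Oc1c(O)c(Br)c(CCc2c(Br)c(O)c(O)c(Br)c2Br)c(Br)c1Br`: 10200 nM
Compound 3 `COCc1c(Br)c(O)c(O)c(Br)c1Cc1c(Br)c(O)c(O)c(Br)c1Br`: 10500 nM

All three compounds share a heavily brominated catechol core and were tested in a functional assay; on this read-out lower numbers stand for stronger inhibition and higher numbers for weaker inhibition. Compound 1 gives 18500 nM, the highest number of the three. Its gaps to compound 3 and to compound 2 are both within the usual scatter of repeated measurements, so the three compounds cannot be told apart on these numbers.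

The next compound, compound 4 `CS(=O)(=O)Cc1c(Br)c(O)c(O)c(Br)c1Br`, keeps the core of compound 1 and changes only the group hanging from the saturated chain carbon bound to an aromatic carbon. The change is methylsulfonyl in place of 2-oxopyrrolidin-1-yl on a saturated chain carbon bound to an aromatic carbon. Going by the values given here, no pair among the measured compounds differs in a single place, so there is no measured step that would show how this kind of swap moves the read-out. On that footing the expectation is a step of no clear size in either direction, most likely staying within the scatter.

Compound 4 is therefore estimated at 20000 nM, with a range from 7000 nM to 60000 nM. The step this estimate means, a 1.1-fold higher number from compound 1 to compound 4 (0.03 log units; within the scatter), is expected to be small.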

Compound 4, half-maximal inhibitory concentration: 24000 nM
Beside the measured number, compound 4's estimate is 1.2-fold (0.08 log units) below it; the measured number falls inside the stated range.
By their numbers in this assay, from the lowest: compounds 2, 3, 1 and 4 (each within the scatter of the next, the first and the last beyond it).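

Going by these compounds alone, this is the first measured step in which only one place changes: in this assay, methylsulfonyl in place of 2-oxopyrrolidin-1-yl on a saturated chain carbon bound to an aromatic carbon gives a 1.3-fold higher number from compound 1 to compound 4 (0.11 log units; within the scatter) and so leaves compound 1 and compound 4 indistinguishable on this read-out. The two groups are built quite differently, with 6 heavy atoms and a five-membered non-aromatic ring in one and 4 heavy atoms, sulfur and no ring in the other, so at this place at least these two very different groups give the same result within the scatter. Nothing measured alongside these compounds offers an explanation for this result.

As far as these compounds go, both groups carry no net charge and have 0 hydrogen-bond donors, so it remains open whether an amine or a carboxylic acid on the same saturated chain carbon would also stay level with compound 1. A single swap also cannot show whether any other group at this place, such as a longer chain, would move the number beyond the scatter in either direction.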